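Trifluoromethoxy for bromo on a fused aromatic ring

The source may report more compounds than this note shows. Statements on the series, on what has been measured and on what is new or still open speak of the compounds shown alone.

Compound 1 `COCCOc1ccc2c(c1)OC(COc1ccc(CCC(=O)O)c(F)c1)CC2` gives 2370 nM. Compound 2 `CC#C[C@H](CC(=O)O)c1ccc(OC[C@@H]2COc3ccc(Cl)cc3O2)cc1` gives 5040 nM. Compound 3 `CC#C[C@@H](CC(=O)O)c1ccc(OC[C@H]2COc3ccc(Br)cc3O2)cc1` gives 210 nM.

These three numbers come from a functional assay on HEK293 cells for agonist activity at Free fatty acid receptor 1 (Homo sapiens), read by fluorescence and calcium flux, with a stated time of 10 min; on this read-out lower numbers stand for an effect already at smaller amounts and higher numbers for an effect only at larger amounts of compound. Among them compound 3 stands lowest; compound 1 lies nearest to it with a number that is higher by a margin beyond the scatter, and compound 2 lies furthest, higher by a larger margin that is also beyond the scatter. Compound 2 and compound 3 differ in more than one place, so their two values are simply reported side by side and no single change is singled out for the gap.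

The unmeasured compound 4 `CC#C[C@@H](CC(=O)O)c1ccc(OC[C@H]2COc3ccc(OC(F)(F)F)cc3O2)cc1` arises from compound 3 by one change: trifluoromethoxy in place of bromo on an aromatic carbon. Among the measured compounds shown here, no measured pair in this set shows such a change on its own, so the expectation rests on the standing of compound 3 alone. The bromo group of compound 3 and the trifluoromethoxy group of compound 4 are both single substituents on the same fused aromatic ring, and a step of modest size, if any, is expected in this assay, with no clear direction favoured beyond the scatter. The step of a 1.2-fold lower number from compound 3 to compound 4 (0.07 log units; within the scatter) is therefore expected to be small. Compound 4 is estimated at 180 nM, with a range from 50 nM to 650 nM, anchored on compound 3 and its value of 210 nM.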

Compound 4, half-maximal effective concentration: 700 nM
For compound 4 the middle estimate is 3.9-fold (0.59 log units) below the measured one; the measured number lies above the stated range.
By their numbers in this assay, from the lowest: compound 3; then compound 4; then compound 1; then compound 2.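

In this assay, among the compounds shown here, the exchange of bromo for trifluoromethoxy on this aromatic carbon gives a 3.3-fold higher number from compound 3 to compound 4 (0.52 log units; beyond the scatter), the first step in the set that isolates a single change. It shows that the position, meta to a fused ring and para to a fused ring, is sensitive to the group it carries: with the rest of the molecule unchanged, replacing one bromine atom with a group of five heavy atoms that includes a hydrogen-bond acceptor moves the number by a modest amount beyond the scatter, and the higher number belongs to the trifluoromethoxy compound. No measurement at hand speaks to the origin of this step.

With only one pair at this position, the compounds shown leave open whether the number tracks the size of the substituent, its acceptor atom or some other feature of it. They also leave open what a nitrile, a methyl group or an amine on the same aromatic carbon would give in this assay, and whether any of these would match or improve on the bromo group of compound 3.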